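This account rests on a few compounds, and the source may have more. Where it says the series, first, only, none or still open, it means among the compounds named here.

Compound 1 `O=C(/C=C/c1ccc2c(c1)B(O)OC2)c1ccc(O)c(O)c1`: in an ADME assay on L929 cells (Mus musculus) for cytotoxicity, read by resazurin assay, with a stated time of 72 h (a higher number here means a weaker inhibitor, a lower number a stronger inhibitor), compound 1 gives > 10 ug/mL, a limit of the assay.
Compound 2 `O=C(/C=C/c1ccc2c(c1)B(O)OC2)c1ccc(O)cc1`: in this assay compound 2 gives > 10 ug/mL, a limit of the assay.
Compound 3 `O=C(/C=C/c1ccc2c(c1)B(O)OC2)c1cccc(F)c1`: in this assay compound 3 gives > 10 ug/mL, a limit of the assay.

Compound 2 thus stands at the limit in this assay, as do the other two measured compounds, which is the limit of > 10 ug/mL in this assay, at which 3 of the 3 values shown sit. Compound 4 `CC(=O)Nc1ccc(C(=O)/C=C/c2ccc3c(c2)B(O)OC3)cc1` differs from compound 2 by acetamido in place of hydroxy on an aromatic carbon. Within the data shown here, the two measured steps that touch compound 2, a step that the two limits leave unreadable from compound 1 to compound 2 and a step that the two limits leave unreadable from compound 2 to compound 3, are both unreadable, so their sizes give no guidance, and no measured step involves an acetamido group. The step from compound 2 to compound 4 is therefore expected to be a step that the limit leaves unreadable from compound 2 to compound 4, with compound 4 most likely remaining at the limit. Compound 4 is estimated at 20 ug/mL, within a range from 10 ug/mL to 50 ug/mL.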

Compound 4, half-maximal inhibitory concentration: > 10 ug/mL
Compound 4 ended at the assay's limit (the forecaster's own chance of this, stated with the estimate: 80%); the middle value does not contradict the limit.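

Among these compounds, compound 4 sits at the same limit as compound 2 in this assay, so no step between compound 2 and compound 4 can be read. The compounds shown leave open whether their cytotoxicity differs at all, since all that is seen is a single ceiling: the limit of > 10 ug/mL in this assay, at which 4 of the 4 values shown sit.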